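The source may report more compounds than this note shows. Statements on the series, on what has been measured and on what is new or still open speak of the compounds shown alone.

Compound 2 `Cc1cc(N2CC[C@H](N3CCC[C@@H]3C)C2)ccc1NC(=O)c1cc(C)n(C)n1` is the weakest binder of the three measured here: in an assay on CHO cells for displacement of a labelled ligand from histamine receptor H3 (Macaca mulatta), read by scintillation counting, with a stated time of 1 h (on this read-out higher numbers stand for weaker inhibition and lower numbers for stronger inhibition), compound 2 gives 10.8 nM. Compound 1 `Cc1cc(N2CC[C@H](N3CCC[C@@H]3C)C2)ccc1NC(=O)c1ccoc1` gives 1.8 nM, and compound 3 `Cc1nc(N2CC[C@H](N3CCC[C@@H]3C)C2)ccc1NC(=O)c1cccc2ccccc12`, which carries a different core, gives 4.2 nM. Among the compounds with values here, the one step measured on a common core, a 6.0-fold higher number from compound 1 to compound 2 (0.78 log units; beyond the scatter), shows that exchanging the ring on the carbonyl carbon moves the number beyond the scatter.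

Compound 4 `Cc1nc(C(=O)Nc2ccc(N3CC[C@H](N4CCC[C@@H]4C)C3)cc2C)co1` differs from compound 2 by 2-methyl-1,3-oxazol-4-yl in place of 1,5-dimethyl-1H-pyrazol-3-yl on a carbonyl carbon. Within the data shown here, no measured pair reports this exact exchange. Among the measured compounds shown here, the only step that bears on it is a 6.0-fold higher number from compound 1 to compound 2 (0.78 log units; beyond the scatter), which shows that an oxygen-containing ring on this carbonyl carbon gave a lower number than the dimethylpyrazole; the new ring also contains oxygen, so some recovery toward compound 1 is expected, but the new ring is not the same as that of compound 1, so the full step is not assumed. The expected change is a 2.2-fold lower number from compound 2 to compound 4 (0.33 log units; beyond the scatter). For compound 4 the estimate in this assay is therefore 5 nM, with a range from 1.5 nM to 15 nM.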

Compound 4, inhibition constant: 4.6 nM
The estimate for compound 4 lay 1.1-fold (0.04 log units) above the measured number; the measured number falls inside the stated range.
By their numbers in this assay, from the lowest: compound 1; then compounds 3 and 4 (each within the scatter of the next); then compound 2.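

In this assay the exchange of 1,5-dimethyl-1H-pyrazol-3-yl for 2-methyl-1,3-oxazol-4-yl on the carbonyl carbon gives a 2.3-fold lower number from compound 2 to compound 4 (0.37 log units; beyond the scatter) and so shows that furan-3-yl is not the only ring here that gives a lower number than the dimethylpyrazole. The same oxazole does not reach the number of the furan, with a 2.6-fold higher number from compound 1 to compound 4 (0.41 log units; beyond the scatter) on the shared core, so the three rings fall in the order furan-3-yl, 2-methyl-1,3-oxazol-4-yl, 1,5-dimethyl-1H-pyrazol-3-yl, each step beyond the scatter. Nothing at hand explains this order.

Open, as far as these compounds go, is whether a pyridyl ring or an open-chain acetyl group on this carbonyl carbon would fit into the same order. Also open, from the compounds shown here alone, is whether furan-3-yl and 2-methyl-1,3-oxazol-4-yl keep this order on the core of compound 3.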